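Phenoxy in Place of Trifluoromethyl on a Weak Series

A few compounds are considered here, and "the series" means these few. Any claim that something is new, unique, unknown or untested is made for them only; others in the source may bear on it.

Compound 1, `Cc1cc(Cl)ccc1Nc1ncc(C(F)(F)F)c(N2Cc3cccc(N(C)S(C)(=O)=O)c3C2)n1`, gives 25500 nM in a functional assay on A549 cells (Homo sapiens) for antiproliferative activity, read by spectrophotometry, with a stated time of 2 days; a lower number here means a stronger inhibitor of growth, a higher number a weaker inhibitor of growth.
Compound 2, `COc1ccc(C(F)(F)F)cc1Nc1ncc(C(F)(F)F)c(N2Cc3cccc(N(C)S(C)(=O)=O)c3C2)n1`, sits at a limit of this assay, > 30000 nM.
Compound 3, `CN(c1cccc2c1CN(c1nc(Nc3cccc(C(F)(F)F)c3)ncc1C(F)(F)F)C2)S(C)(=O)=O`, likewise sits at a limit of this assay, > 30000 nM.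

Compound 3 thus stands at the edge of what this assay can report; a limit means only that no growth inhibition was reached within the tested range, a position that the limit of > 30000 nM in this assay, at which 2 of the 3 values shown sit, shows for two of the three compounds. Compound 4, `CN(c1cccc2c1CN(c1nc(Nc3cccc(Oc4ccccc4)c3)ncc1C(F)(F)F)C2)S(C)(=O)=O`, differs from compound 3 in one place: phenoxy in place of trifluoromethyl on an aromatic carbon.

Going by the values given here, none of the measured steps changes this group alone. The step of an at least 1.1-fold higher number from compound 1 to compound 2 (0.07 log units; that floor lies within the scatter) and the step of an at least 1.1-fold higher number from compound 1 to compound 3 (0.07 log units; that floor lies within the scatter) each exchange the whole aryl group attached to the nitrogen, and the step that the two limits leave unreadable from compound 2 to compound 3 runs between two limits. So nothing in the data reads the size of a phenoxy for trifluoromethyl exchange. Given that compound 3 is a limit, the step of an at least 1.3-fold lower number from compound 3 to compound 4 (0.13 log units; that floor lies within the scatter) is expected to be unreadable in kind, with compound 4 likely remaining weak. Compound 4 is estimated at 22000 nM, within 5000 nM to 40000 nM.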

Compound 4, concentration for 50% growth inhibition: 19000 nM
Beside the measured number, compound 4's estimate is 1.2-fold (0.06 log units) above it, within the range that was stated.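

In this assay compound 4 gives a readable number, 19000 nM, with phenoxy on the aromatic carbon that carries trifluoromethyl in compound 3. Going by these compounds, compound 3 is a limit, so the exchange can be sized from one side only, as an at least 1.5-fold lower number from compound 3 to compound 4 (0.19 log units; that floor lies within the scatter), and the true size of the step stays unknown. What this adds is that a group with a six-membered aromatic ring can stand at this place while the compound still gives a measured value, although that value remains high.

The compounds shown leave open how much of this rests on the oxygen and how much on the added ring, and what a benzyloxy group would do at the same carbon. They also leave open what an amine or a carboxylic acid on the ring of the phenoxy would do.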